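Three Inactive Amides and a Methylsulfonyl Newcomer

The source may report more compounds than this note shows. Statements on the series, on what has been measured and on what is new or still open speak of the compounds shown alone.

Three compounds have been run in a functional assay on T47D cells (Homo sapiens) for antiproliferative activity, read by MTT assay, with a stated time of 72 h (a lower number here means a stronger inhibitor, a higher number a weaker inhibitor), and each gives only a limit.
Compound 1 `O=C(Nc1ccc(Cl)c(-c2nnc3c(Cl)cccn23)c1)c1ccccn1`: > 100000 nM, a limit of the assay.
Compound 2 `O=C(Nc1ccc(Cl)c(-c2nnc3c(Cl)cccn23)c1)c1c(F)cccc1Cl`: > 100000 nM, a limit of the assay.
Compound 3 `O=C(Nc1ccc(Cl)c(-c2nnc3c(Cl)cccn23)c1)c1cccnc1Cl`: > 100000 nM, a limit of the assay.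

Compound 3 thus stands at the limit of > 100000 nM in this assay, at which 3 of the 3 values shown sit, and with no number behind any of the three, none can be ranked against another. The steps among them, a step that the two limits leave unreadable from compound 1 to compound 2, a step that the two limits leave unreadable from compound 1 to compound 3 and a step that the two limits leave unreadable from compound 2 to compound 3, cannot be sized. Compound 4 `CS(=O)(=O)c1cccc(C(=O)Nc2ccc(Cl)c(-c3nnc4c(Cl)cccn34)c2)c1` differs from compound 3 by 3-(methylsulfonyl)phenyl in place of 2-chloropyridin-3-yl on a carbonyl carbon. Within the data shown here, no measured step speaks to this change except the three that cannot be read, so all that can be said is that every group placed so far on the carbonyl carbon has left the value at the limit. Compound 4 is expected to sit there as well, at about 100000 nM, between 40000 nM and 300000 nM. The expected step of a number no higher from compound 3 to compound 4 (the limit leaves the size open) is therefore estimated as none beyond the scatter, most likely reported again as a limit.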

Compound 4, half-maximal inhibitory concentration: > 100000 nM
Compound 4 gave a limit, no number; the forecaster's own chance of this, stated with the estimate: 75%; the middle value sits exactly at the limit.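

The steps linking compound 4 to compound 1, compound 2 and compound 3 cannot be read in this assay, where all four give only a limit: the limit of > 100000 nM in this assay, at which 4 of the 4 values shown sit.

The compounds shown leave open what number any of them would reach, and whether the groups on the carbonyl carbon differ at all.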